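Phenylsulfonyl for alkenyloxy on the core: compound 3

The compounds below may be only part of what the source reports. "The series", "measured", "known", "first", "only" and "open" are said of these compounds alone.

Within the data shown here, only two compounds carry numbers in a functional assay on LoVo cells (Homo sapiens) for inhibition, read by colorimetric assay and MTT assay, with a stated time of 72 h; on this read-out higher numbers stand for weaker inhibition and lower numbers for stronger inhibition. Compound 1 `C=CCCCCOc1ccccc1-c1cnc(OCCC=C)n1C` gives 12000 nM in this assay, and compound 2 `C=CCCOc1ncc(-c2ccccc2OC)n1C` gives 24000 nM. Among the measured compounds shown here, the one measured step is a 2.0-fold higher number from compound 1 to compound 2 (0.30 log units; within the scatter), from hydrogen in place of pent-4-en-1-yl on a saturated chain carbon bound to an oxygen on an aromatic ring; on these numbers compound 1 and compound 2 cannot be told apart. Compound 3 `C=CCCCCOc1ccccc1-c1cnc(S(=O)(=O)c2ccccc2)n1C` differs from compound 1 by phenylsulfonyl in place of (but-3-en-1-yl)oxy on an aromatic carbon. The measured step touches a chain on an aromatic oxygen, not the group on the core, so nothing in the series bears on this exchange and no direction can be read from it. The step from compound 1 to compound 3 is therefore expected to be no change at the digits printed from compound 1 to compound 3 (within the scatter), with a wide range around no change. Compound 3 is estimated at 12000 nM in this assay, between 3000 nM and 50000 nM.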

Compound 3, half-maximal inhibitory concentration: 27000 nM
For compound 3 the middle estimate is 2.3-fold (0.35 log units) below the measured one; low and high end bracket the measured number.
By their numbers in this assay, from the lowest: compounds 1, 2 and 3 (each within the scatter of the next, the first and the last beyond it).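

In this assay, among these compounds, the aromatic carbon between two ring nitrogen atoms now has a reading of its own: phenylsulfonyl in place of (but-3-en-1-yl)oxy gives a 2.3-fold higher number from compound 1 to compound 3 (0.35 log units; beyond the scatter), a modest step and the only single-place step beyond the scatter. The position therefore accepts an exchange of an open chain of 5 heavy atoms for a group of 9 heavy atoms with a six-membered aromatic ring, at the cost of only this modest weakening. Nothing available accounts for the size or direction of the step.

On these data alone, with a single exchange at this carbon, it remains open whether the step follows the sulfonyl link or the phenyl ring, and how an amine, a carboxylic acid or a longer alkenyloxy chain there would read. As far as these compounds go, the step at the chain on the aromatic oxygen is known only with (but-3-en-1-yl)oxy on the core, so its size alongside phenylsulfonyl is also open.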